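A Chloro Substituent on the Benzyl Group of Compound 2

This account rests on a few compounds, and the source may have more. Where it says the series, first, only, none or still open, it means among the compounds named here.

Compound 1, `Cc1ccc(S(=O)(=O)Nc2ccc3c(c2)C(=O)N(CCOc2ccc(O)cc2)C3=O)cc1`: in an assay on isolated protein for inhibition of lactase/phlorizin hydrolase (Rattus norvegicus), read by colorimetric assay (on this read-out lower numbers stand for stronger inhibition and higher numbers for weaker inhibition), compound 1 gives 100000 nM.
Compound 2, `Cc1ccc(S(=O)(=O)Nc2ccc3c(c2)C(=O)N(Cc2ccccc2)C3=O)cc1`: in this assay compound 2 reaches only the limit > 200000 nM.
Compound 3, `O=C1c2ccc([N+](=O)[O-])cc2C(=O)N1CCNc1ccccc1`: in this assay compound 3 likewise stops at the limit > 200000 nM.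

Compound 2 stands at the upper limit of this assay; its number is a limit, not a measured value, as the limit of > 200000 nM in this assay, at which 2 of the 3 values shown sit, records. Compound 4, `Cc1ccc(S(=O)(=O)Nc2ccc3c(c2)C(=O)N(Cc2ccc(Cl)cc2)C3=O)cc1`, differs from compound 2 by chloro in place of hydrogen on an aromatic carbon. Among the compounds with values here, the only measured step, an at least 2.0-fold higher number from compound 1 to compound 2 (0.30 log units; that floor lies within the scatter), concerns a different change and offers no guidance on chloro in place of hydrogen. No step beyond the scatter is therefore expected in this assay, a step that the limit leaves unreadable from compound 2 to compound 4. Compound 4 is estimated at 250000 nM, between 100000 nM and 600000 nM, and most probably again only a limit.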

Compound 4, half-maximal inhibitory concentration: 155000 nM
Compound 4: the middle estimate sits 1.6-fold (0.21 log units) above what was measured, within the range that was stated.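

Within the data shown here, with chloro in place of hydrogen, compound 4 gives a number inside the range of this assay, and the step of an at least 1.2-fold lower number from compound 2 to compound 4 (0.11 log units; that floor lies within the scatter) is the first reading for this aromatic carbon. Setting the 4-chlorophenyl group in place of the (4-hydroxyphenoxy)methyl group gives a 1.6-fold higher number from compound 1 to compound 4 (0.19 log units; within the scatter) and so does not tell the two groups apart on this read-out.

On these data alone, whether a methoxy group or a carboxylic acid at this place would move the number further stays open. The true size of the chloro step also stays open because compound 2 carries only a limit: the limit of > 200000 nM in this assay, at which 2 of the 4 values shown sit.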